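Swapping a thiazole for a pyrazine on a shared core

A few compounds are considered here, and "the series" means these few. Any claim that something is new, unique, unknown or untested is made for them only; others in the source may bear on it.

Of the compounds shown here, three built on one shared core have been measured in an ADME assay on the whole organism (plasma, Rattus norvegicus) for protein binding, using cassette dosing, at a dose of 1 mg/kg; on this read-out higher numbers stand for a larger free fraction and lower numbers for a smaller free fraction. Compound 1 `C[C@@H](Cn1c(=O)[nH]/c(=N\c2ccc(Oc3nccs3)cc2)n(Cc2ccc(Cl)cc2)c1=O)C(=O)O` gives 0.006 in this assay, which is the largest of the three numbers. Compound 3 `CC(C)Oc1ccc(/N=c2\[nH]c(=O)n(C[C@H](C)C(=O)O)c(=O)n2Cc2ccc(Cl)cc2)cc1Cl` gives 0.003, a gap from compound 1 that falls within the usual scatter of the measurement, so the two cannot be ranked against each other. Compound 2 `CC(C)Oc1ccc(Nc2nc(=O)n(CCO)c(=O)n2Cc2ccc(Cl)cc2)cc1Cl` gives 0.001, and here the gap from compound 1 lies beyond the scatter.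

Compound 4 `C[C@@H](Cn1c(=O)[nH]/c(=N\c2ccc(Oc3cnccn3)cc2)n(Cc2ccc(Cl)cc2)c1=O)C(=O)O` has not yet been measured in this assay. It differs from compound 1 in one place: pyrazin-2-yl in place of 1,3-thiazol-2-yl on an oxygen on an aromatic ring. For the measured compounds named here, no measured pair in this set reports the effect of such a change, so the expectation rests on the size of the step alone. Compound 4 is expected to show a step from compound 1 of a 1.2-fold higher number from compound 1 to compound 4 (0.07 log units; within the scatter), which is not expected to exceed the scatter. Compound 4 is therefore estimated at 0.007 in this assay, with a range from 0.003 to 0.016.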

Compound 4, unbound fraction: 0.018
Compound 4: middle estimate off by 2.6-fold (0.41 log units), on the low side, outside the stated range (above it).
By their numbers in this assay, from the lowest: compound 2; then compounds 3 and 1 (each within the scatter of the next); then compound 4.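

Read in this assay the change from 1,3-thiazol-2-yl to pyrazin-2-yl on this oxygen gives a 3.0-fold higher number from compound 1 to compound 4 (0.48 log units; beyond the scatter) with the rest of the molecule unchanged. For the compounds shown here, the earlier compounds offered no pair differing in one place, so this is the only direct reading of what this position can do, and it shows that the ring held on this oxygen can move the unbound fraction by more than the usual scatter. Nothing available here accounts for the size or direction of this step.

On these data alone, whether a pyridin-2-yl ring or a plain phenyl ring on the same oxygen would sit nearer compound 1 or compound 4 stays open. So does whether the same swap would give a similar step on a compound carrying a 2-hydroxyethyl chain instead of the carboxylic acid chain.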